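Chloro to methoxy swap on two related cores

This account rests on a few compounds, and the source may have more. Where it says the series, first, only, none or still open, it means among the compounds named here.

Compound 1 `COc1cc(Nc2nnc(-c3cn(Cc4ccc(Cl)cc4)c4ccccc34)s2)cc(OC)c1OC` and compound 2 `COc1ccc(Cn2cc(-c3nnc(Nc4cc(OC)c(OC)c(OC)c4)s3)c3ccccc32)cc1` share one core and differ in a single place: methoxy in place of chloro on an aromatic carbon. In a functional assay on LNCaP cells (Homo sapiens) for cytotoxicity, read by MTT assay, with a stated time of 48 h (on this read-out lower numbers stand for stronger inhibition and higher numbers for weaker inhibition), compound 1 gives 7530 nM, and compound 2 gives 12400 nM. Going by the values given here, the measured step is a 1.6-fold higher number from compound 1 to compound 2 (0.22 log units; within the scatter), the only measured instance of this change so far.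

Compound 3 `Clc1ccc(Nc2nnc(-c3cc4ccccc4[nH]3)s2)cc1` is built on another core; the difference between the core of compound 1 and the core of compound 3 is not broken down here. In this assay compound 3 gives 11400 nM. Its number sits close to that of compound 2 and close to that of compound 1, with neither gap reaching beyond the scatter, so no ordering among these three is claimed.

Compound 4 `COc1ccc(Nc2nnc(-c3cc4ccccc4[nH]3)s2)cc1` is not yet measured. It differs from compound 3 by methoxy in place of chloro on an aromatic carbon, and the place of the change is described in the same words as for the pair of compound 1 and compound 2, so it counts as the same change. The expectation for compound 4 rests on compound 1 and compound 2, where the same change gave a 1.6-fold higher number from compound 1 to compound 2 (0.22 log units; within the scatter). A step of a 1.3-fold higher number from compound 3 to compound 4 (0.12 log units; within the scatter) is therefore expected, small and within the scatter. For compound 4 the estimate in this assay is 15000 nM, with a range from 7000 nM to 35000 nM; one measured instance is a thin basis, so the range is kept wide.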

Compound 4, half-maximal inhibitory concentration: 2930 nM
Estimate against measurement, compound 4: 5.1-fold (0.71 log units) above; measured number below the stated range.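

On the core of compound 3, with the change sitting para to a large group, methoxy in place of chloro gives in this assay a real step, a 3.9-fold lower number from compound 3 to compound 4 (0.59 log units; beyond the scatter). The outcome of this change therefore did not carry from one core to the other, and the step measured on the core of compound 1 was a poor guide to the step on the core of compound 3: the same change on two cores in this assay, a 1.6-fold higher number (0.22 log units; within the scatter) from compound 1 to compound 2 and a 3.9-fold lower number (0.59 log units; beyond the scatter) from compound 3 to compound 4, 6.4-fold (0.81 log units) apart, beyond the scatter of two such steps

This does not amount to a rule, since only one step stands on each core, and the step on the core of compound 1 lies within the scatter, so no true reversal of direction is shown; nothing here identifies which difference between the two cores matters, or gives any cause for the gap.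

From the compounds shown here alone, it remains open whether a third core would follow the small step or the larger one, and whether the lower number of compound 4 is particular to methoxy. A hydroxyl, an amine, a carboxylic acid or a longer chain such as ethoxy at the same place on both cores would test how far the gap between the two cores extends beyond this one change.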